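Dimethylamino for Amino: What Solubility to Expect

The compounds below may be only part of what the source reports. "The series", "measured", "known", "first", "only" and "open" are said of these compounds alone.

Within the data shown here, compound 2 `Cc1cc(NCc2ccccn2)n2ncc(-c3cccc(N)c3)c2n1` holds the only solubility number among the measured compounds: in a physicochemical assay for solubility, read by HPLC, using the shake flask method, measured as kinetic solubility, with a stated time of 2 h, at pH 7.4 (on this read-out higher numbers stand for higher solubility and lower numbers for lower solubility), compound 2 gives 160000 nM. Compound 1 `Cc1cc(NCc2ccccn2)n2ncc(-c3ccc(C#N)cc3)c2n1` is the other measured compound, and in this assay compound 1 reaches only a limit, < 5000 nM. That limit is the limit of < 5000 nM in this assay, at which 1 of the 2 values shown sits. Among the measured compounds shown here, the single measured step therefore rests on one number and one limit: an at least 32-fold higher number from compound 1 to compound 2 (1.50 log units; beyond the scatter), the change being 3-aminophenyl in place of 4-cyanophenyl.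

Compound 3 `Cc1cc(NCc2ccccn2)n2ncc(-c3cccc(N(C)C)c3)c2n1` has not yet been measured in this assay. It differs from compound 2 by dimethylamino in place of amino on an aromatic carbon. For the measured compounds named here, the measured step from compound 1 to compound 2 exchanges the whole aryl substituent, whereas the change to compound 3 keeps the 3-aminophenyl and only adds two carbons to its nitrogen; no measured step covers dimethylamino in place of amino. Compound 3 is therefore expected to stay on the soluble side of the measured pair, with a moderate decrease estimated as a 2.7-fold lower number from compound 2 to compound 3 (0.43 log units; beyond the scatter). The estimate for compound 3 in this assay is 60000 nM, within 15000 nM to 200000 nM.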

Compound 3, solubility: 94600 nM
Estimate against measurement, compound 3: 1.6-fold (0.20 log units) below; measured number inside the range.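

In this assay, dimethylamino in place of amino on an aromatic carbon gives a 1.7-fold lower number from compound 2 to compound 3 (0.23 log units; within the scatter), so at this place, meta to a large group, amino with 1 hydrogen-bond donor and dimethylamino with 0 hydrogen-bond donors cannot be told apart on this read-out. Set against 4-cyanophenyl, 3-(dimethylamino)phenyl gives an at least 18-fold higher number from compound 1 to compound 3 (1.27 log units; beyond the scatter), so the large step first seen with 3-aminophenyl now appears with a second group on the same nitrogen position of the aryl ring. That comparison has only one true number, and compound 1 stands at a limit of the assay: the limit of < 5000 nM in this assay, at which 1 of the 3 values shown sits.

Each step from compound 1 exchanges the aryl substituent as a whole, so the compounds shown leave open how much of the large difference goes with the group itself and how much with its place on the ring. They also leave open how a carboxylic acid or a morpholine on the same aromatic carbon would read in this assay, and whether such a group would stay as close to amino as dimethylamino does.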